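The source may hold more compounds than are shown below. What is called first, only, known or untested is meant among the compounds shown, and "the series" means these compounds.

Measured so far:
- Compound 1, `Cc1cc(O)c(C(=O)/C=C/c2cccc(Cl)c2)c(-c2ccccc2)c1C(=O)/C=C/c1cccc(Cl)c1`: 4670 nM in a functional assay on MDA-MB-231 cells (Homo sapiens) for cytotoxicity, read by MTT assay, with a stated time of 24 h; on this read-out higher numbers stand for weaker inhibition and lower numbers for stronger inhibition
- Compound 2, `Cc1cc(O)c(C(=O)/C=C/c2ccc3ccccc3c2)c(-c2ccccc2)c1C(=O)/C=C/c1ccc2ccccc2c1`: 30000 nM in this assay

Among the compounds with values here, compound 2 gives the higher of the two numbers recorded in this assay; the only other compound, compound 1, sits lower by a margin given as beyond the scatter. Within the data shown here, nothing more can be read from this pair, since they differ at more than one place and no single step between them is defined.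

Compound 3, `Cc1cc(O)c(C(=O)/C=C/c2ccc3ccccc3c2)c(-c2ccc(Cl)cc2)c1C(=O)/C=C/c1ccc2ccccc2c1`, is not yet measured. It differs from compound 2 in one place: chloro in place of hydrogen on an aromatic carbon, so the pendant phenyl becomes 4-chlorophenyl while both enone arms are kept. Among the measured compounds shown here, there is no measured pair that isolates this change, so the size and direction of its effect are unknown. The working assumption is a step from compound 2 to compound 3 of no more than the usual scatter, with no preferred direction. Compound 3 is therefore expected to give about 25000 nM in this assay, with a plausible range of 8000 nM to 80000 nM. The implied step a 1.2-fold lower number from compound 2 to compound 3 (0.08 log units; within the scatter) is an estimate only and is expected to stay within the scatter.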

Compound 3, half-maximal inhibitory concentration: "not active" (no number reported)
The entry for compound 3 holds no number; there is nothing to compare the estimate with.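

Within the data shown here, compound 3 is recorded in this assay as "not active", with no number reported; no step from compound 2 to compound 3 can be read. No measured evidence bears on this result. The compounds shown leave open the size and direction of any effect of changing phenyl to 4-chlorophenyl in this series.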